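Adding a chloro to the fluorophenyl ring of compound 1

This account rests on a few compounds, and the source may have more. Where it says the series, first, only, none or still open, it means among the compounds named here.

Of the compounds shown here, three sharing one core have been tested for cytotoxicity in a functional assay on MCF7 cells (Homo sapiens) for cytotoxicity, read by MTT assay, with a stated time of 24 h; on this read-out lower numbers stand for stronger inhibition and higher numbers for weaker inhibition. Compound 1 `Fc1ccc(-n2cc(COc3ccccc3-c3nc4ccccc4s3)nn2)cc1` gives 26200 nM, compound 2 `COc1ccc(-c2cc(COc3ccccc3-c3nc4ccccc4s3)on2)cc1` gives 22100 nM, and compound 3 `Clc1ccc(-c2cc(COc3ccccc3-c3nc4ccccc4s3)on2)cc1` gives 23800 nM. Compound 1 shows the highest of the three numbers, yet its gaps to compound 3 and to compound 2 both fall within the scatter, so the three stand together.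

Compound 4 `Fc1ccc(-n2cc(COc3ccccc3-c3nc4ccccc4s3)nn2)cc1Cl` differs from compound 1 by chloro in place of hydrogen on an aromatic carbon, the 4-fluorophenyl group becoming 3-chloro-4-fluorophenyl. Among the compounds with values here, no measured pair shows exactly a chloro replacing a hydrogen. The closest comparison is a 1.1-fold higher number from compound 2 to compound 3 (0.03 log units; within the scatter), where a chloro stands in place of a methoxy on a different ring of the core and the number barely moved. On that basis a change within the scatter, or at most a modest one in either direction, is expected in this assay.

Compound 4 is therefore estimated at 20000 nM, with a range from 8000 nM to 50000 nM, a step of a 1.3-fold lower number from compound 1 to compound 4 (0.12 log units; within the scatter) that is expected to stay near compound 1.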

Compound 4, half-maximal inhibitory concentration: 27300 nM
Compound 4: middle estimate off by 1.4-fold (0.14 log units), on the low side; the range from low to high includes it.
By their numbers in this assay, from the lowest: compounds 2, 3, 1 and 4 (each within the scatter of the next).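

Chloro in place of hydrogen on the aromatic carbon ortho to the fluoro group gives a 1.0-fold higher number from compound 1 to compound 4 (0.02 log units; within the scatter) in this assay, the first direct reading of this change among these compounds. The earlier pair showed only chloro in place of methoxy on another ring, whereas this step shows that the 4-fluorophenyl group of compound 1 can become 3-chloro-4-fluorophenyl while compound 4 stands together with compound 1. No measured information on the compounds accounts for this result.

Open, going by these compounds, is whether this position tolerates only a single chloro atom or also larger or charged groups, such as an amine, a carboxylic acid or a longer alkyl chain. The compounds shown also leave open whether any change at this position can separate a compound from the others in this assay.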